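Adding a Methoxy Group on Two Different Cores

The source may report more compounds than this note shows. Statements on the series, on what has been measured and on what is new or still open speak of the compounds shown alone.

Compound 1 `CC1=CC[C@H](C(C)(C)NC(=S)N/N=C/c2ccc(O)cc2)CC1` and compound 2 `COc1cc(/C=N/NC(=S)NC(C)(C)[C@H]2CC=C(C)CC2)ccc1O` share one core and differ in a single place: compound 2 carries methoxy in place of hydrogen on an aromatic carbon. In a functional assay on U-251 cells (Homo sapiens) for inhibition, read by sulforhodamine B assay, with a stated time of 48 h (on this read-out higher numbers stand for weaker inhibition of growth and lower numbers for stronger inhibition of growth), compound 1 gives > 100000 nM, which is a limit of the measurement rather than a number. In this assay compound 2 gives 11700 nM. The change therefore made an at least 8.5-fold lower number from compound 1 to compound 2 (0.93 log units; beyond the scatter). Only a lower bound of this step is known because of the limit of > 100000 nM in this assay, at which 2 of the 3 values shown sit.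

Compound 3 `CC1=CC[C@H](C(C)(C)NC(=S)N/N=C(\C)c2ccccc2)CC1` is built on a second core; the difference between the two cores is not broken down here. In this assay compound 3 gives > 100000 nM, again a limit rather than a number. Compound 4 `COc1ccc(/C(C)=N/NC(=S)NC(C)(C)[C@H]2CC=C(C)CC2)cc1` has not been measured; it differs from compound 3 by methoxy in place of hydrogen on an aromatic carbon. This is the same kind of change as from compound 1 to compound 2, but not the same change: in compound 2 the methoxy sits ortho to a hydroxy group and meta to a large group, whereas in compound 4 it sits para to a large group.

Because the earlier step of an at least 8.5-fold lower number from compound 1 to compound 2 (0.93 log units; beyond the scatter) is known only as a lower bound and the surroundings of the new group differ, the step from compound 3 to compound 4 is expected to be an at least 1.6-fold lower number from compound 3 to compound 4 (0.22 log units; that floor lies within the scatter), with wide uncertainty. Compound 4 is estimated to give 60000 nM in this assay. Its expected range runs from 15000 nM to 200000 nM.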

Compound 4, concentration for 50% growth inhibition: 43400 nM
The estimate for compound 4 lay 1.4-fold (0.14 log units) above the measured number; measured number inside the range.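

In this assay, the methoxy change again lowers the number on the second core, with an at least 2.3-fold lower number from compound 3 to compound 4 (0.36 log units; beyond the scatter), so on both cores shown the change points in the same direction. This does not show that the change has the same size on both cores, and two cores are too few to make a rule for the series: the same change on two cores in this assay, an at least 8.5-fold lower number (0.93 log units; beyond the scatter) from compound 1 to compound 2 and an at least 2.3-fold lower number (0.36 log units; beyond the scatter) from compound 3 to compound 4; the limit leaves it open whether they differ. Each step is known only as a lower bound, so neither true size can be read, because each starting compound sits at the upper limit of the measurement: the limit of > 100000 nM in this assay, at which 2 of the 4 values shown sit.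

The compounds shown leave open whether another group in the same place on the ring, such as an ethoxy group, a chlorine atom or an amine, would lower the number by more, by less or not at all. They also leave open how large the methoxy step would be on a core whose starting compound gives a real number rather than a limit.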